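This account rests on a few compounds, and the source may have more. Where it says the series, first, only, none or still open, it means among the compounds named here.

Measured in a functional assay on NCI-H1975 cells (Homo sapiens) for antiproliferative activity, read by CCK-8 assay, with a stated time of 72 h; a lower number here means a stronger inhibitor of growth, a higher number a weaker inhibitor of growth:
- Compound 1 `CCC1C(=O)N(C)c2cnc(-n3ccc4cc(C(=O)NC)ccc43)nc2N1c1ccn(C)n1`: 35700 nM
- Compound 2 `CCNC(=O)c1ccc2c(ccn2-c2ncc3c(n2)N(c2ccn(C)n2)C(CC)C(=O)N3C)c1`: "not active" (no number reported)

Compound 2 stands at the weak end of this small set. In this assay compound 2 is recorded as "not active" (no number reported), with no number, while compound 1, which has methyl on the same nitrogen, gives 35700 nM.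

Compound 3 `CCC1C(=O)N(C)c2cnc(-n3ccc4cc(C(N)=O)ccc43)nc2N1c1ccn(C)n1` has not yet been measured. The structural change is hydrogen in place of ethyl on an amide-type nitrogen, which puts hydrogen in place of ethyl on an amide-type nitrogen, so that ethylcarbamoyl becomes carbamoyl.

With no number for compound 2, the step in this assay cannot be sized directly. Growth inhibition is expected to improve, and by a clear margin, though the uncertainty is wide and a result with no number remains possible. The estimate for compound 3 is 8000 nM, with an expected range from 800 nM to 50000 nM.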

Compound 3, concentration for 50% growth inhibition: "not active" (no number reported)
For compound 3 the study gives words and no number, and the estimate cannot be compared.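

In this assay compound 2 and compound 3 are both recorded as "not active" with no number, so no step can be read between them. The compounds shown leave open whether ethylcarbamoyl and carbamoyl differ at all in growth inhibition. No further evidence bears on this result.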